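Chlorobenzyl sulfanyl variants in the oral artery series

A few compounds are considered here, and "the series" means these few. Any claim that something is new, unique, unknown or untested is made for them only; others in the source may bear on it.

Compound 1 `CC1=C(C(=O)Nc2ccc(Br)cc2)C(c2ccc(Cl)cc2Cl)N=C(SCc2ccccc2)N1` and compound 2 `CC1=C(C(=O)Nc2ccc(Br)cc2)C(c2ccc(Cl)cc2Cl)N=C(SCc2cccc(Cl)c2)N1` share one core; compound 3 `CC1=C(C(=O)Nc2ccc([N+](=O)[O-])cc2)C(c2cccc([N+](=O)[O-])c2)N=C(SCc2ccccc2)N1` and compound 4 `CC1=C(C(=O)Nc2ccc([N+](=O)[O-])cc2)C(c2cccc([N+](=O)[O-])c2)N=C(SCc2ccccc2Cl)N1` share another, and the difference between the two cores is not broken down here. In a functional assay on the whole organism (artery, strain albino) with Rattus norvegicus as the target, with a stated time of 900 min, at a dose of 10 mg/kg by the oral route (on this read-out higher numbers stand for more inhibition at the one dose given (going by the name of the read-out) and lower numbers for less inhibition), compound 1 gives 8.2% and compound 2 gives 7.2%; the change between them is chloro in place of hydrogen on an aromatic carbon, placed meta to a large group, and the step is a number 1 percentage points lower from compound 1 to compound 2 (within the scatter). In this assay compound 3 gives 14.9%; the pairs 3 versus 1 and 3 versus 2 fall within the scatter, so no order is read from them. Compound 4 carries the same kind of change as compound 2, namely (chloro in place of hydrogen on an aromatic carbon), but here the chloro sits ortho to a large group rather than meta to it, so the two places are not identical. Among the compounds with values here, since the one measured example of this change moved the read-out by a number 1 percentage points lower from compound 1 to compound 2 (within the scatter), compound 4 is expected to sit near compound 3, with an estimated step of a number 0.9 percentage points lower from compound 3 to compound 4 (within the scatter). The estimate for compound 4 in this assay is 14%, with a range from 4% to 25%.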

Compound 4, a percentage reported as inhibition, in the whole organism at one dose (the size of the read-out at that dose, not a potency): 7.2%
Compound 4: the middle estimate sits 6.8 percentage points above what was measured; low and high end bracket the measured number.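

In this assay the read-out comes out a number 7.7 percentage points lower from compound 3 to compound 4 (within the scatter) and the earlier step reads a number 1 percentage points lower from compound 1 to compound 2 (within the scatter) on the other core, so adding a chloro to the benzyl ring gives no readable change on either core. The two steps cannot be told apart either: the same change on two cores in this assay, a number 1 percentage points lower (within the scatter) from compound 1 to compound 2 and a number 7.7 percentage points lower (within the scatter) from compound 3 to compound 4, 6.7 percentage points apart, within the scatter of two such steps

This does not show that the change carries over with the same effect, as each core offers a single pair, and the chloro stands ortho to a large group in compound 4 but elsewhere on the ring in compound 2.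

Open remains how the read-out responds to other groups on the benzyl ring, such as a methoxy group, a carboxylic acid or an amine. Also open, going by these compounds, is whether a longer chain between the sulfur and the phenyl ring, or an ethyl group in place of the benzyl, would give a read-out that stands clear of the scatter.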